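This account rests on a few compounds, and the source may have more. Where it says the series, first, only, none or still open, it means among the compounds named here.

Measured so far in an assay on isolated protein for inhibition of aldehyde dehydrogenase 1A1 (Homo sapiens); on this read-out lower numbers stand for stronger inhibition and higher numbers for weaker inhibition: compound 1 `CC(C)C(Sc1nc2c(cnn2C)c(=O)n1-c1ccccc1)c1ccccc1` gives 380 nM; compound 2 `CC(Sc1nc2c(cnn2C)c(=O)n1-c1ccccc1)c1ccncc1` gives 451 nM.

Compound 2 holds the higher of the two numbers, yet its gap to compound 1 lies within the scatter, so the two read alike. On these data alone, compound 3 `CC(Sc1nc2c(cnn2C)c(=O)n1-c1ccccc1)c1ccccc1` is untested. The change from compound 2 is phenyl in place of pyridin-4-yl on a saturated chain carbon bound to a saturated chain carbon and a sulfur. Among the compounds with values here, no step between measured compounds covers this exchange; the expectation rests on compound 1 at 380 nM and compound 2 at 451 nM reading alike. The step from compound 2 to compound 3 is expected to be small, a 1.3-fold lower number from compound 2 to compound 3 (0.11 log units; within the scatter), with no direction beyond the scatter. Compound 3 is estimated at 350 nM, range 150 nM to 800 nM.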

Compound 3, half-maximal inhibitory concentration: 130 nM
For compound 3 the middle estimate is 2.7-fold (0.43 log units) above the measured one; the measured number lies below the stated range.
By their numbers in this assay, from the lowest: compound 3; then compounds 1 and 2 (each within the scatter of the next).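

In this assay, the change at this saturated chain carbon does matter once the other place is held at methyl: a 3.5-fold lower number from compound 2 to compound 3 (0.54 log units; beyond the scatter) with phenyl in place of pyridin-4-yl. Methyl in place of isopropyl gives a 2.9-fold lower number from compound 1 to compound 3 (0.47 log units; beyond the scatter) on the same phenyl-bearing carbon, so the alike numbers of compound 1 and compound 2 conceal two separate steps, each beyond the scatter when taken from compound 3.

Open, on these data alone, is whether an ethyl in place of that methyl, or a fluorine or an amine on the phenyl, would keep the number of compound 3 at 130 nM. No measurement at hand accounts for either step.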